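Swapping Trifluoromethyl for Chloro on Two Related Cores

A few compounds are considered here, and "the series" means these few. Any claim that something is new, unique, unknown or untested is made for them only; others in the source may bear on it.

Compound 2 `COc1cc(O)cc(O)c1C(=O)/C=C/c1ccc(C(F)(F)F)cc1` and compound 1 `COc1cc(O)cc(O)c1C(=O)/C=C/c1ccc(Cl)cc1` share one core. In a functional assay on A549 cells (Homo sapiens) for inhibition, read by MTT assay, with a stated time of 72 h (a lower number here means a stronger inhibitor, a higher number a weaker inhibitor), compound 2 gives 15400 nM and compound 1 gives 18200 nM, so the change chloro in place of trifluoromethyl on an aromatic carbon made a step of a 1.2-fold higher number from compound 2 to compound 1 (0.07 log units; within the scatter). Compound 3 `COc1cc(OC)c(C(=O)/C=C/c2ccc(C(F)(F)F)cc2)c(OC)c1` has a second core; how it differs from the core of compound 2 is not broken down here. In this assay compound 3 gives 14200 nM. Compound 4 `COc1cc(OC)c(C(=O)/C=C/c2ccc(Cl)cc2)c(OC)c1` has not yet been measured; it carries the same change as before, (chloro in place of trifluoromethyl on an aromatic carbon). The step from compound 3 to compound 4 is expected to be about a 1.2-fold higher number from compound 3 to compound 4 (0.08 log units; within the scatter), because the same change gave a 1.2-fold higher number from compound 2 to compound 1 (0.07 log units; within the scatter) on the first core, a step that is within the usual scatter. In this assay compound 4 is therefore estimated at 17000 nM, between 9000 nM and 34000 nM.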

Compound 4, half-maximal inhibitory concentration: 13300 nM
Beside the measured number, compound 4's estimate is 1.3-fold (0.11 log units) above it; the range from low to high includes it.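

In this assay, putting chloro in place of trifluoromethyl on the second core gives a 1.1-fold lower number from compound 3 to compound 4 (0.03 log units; within the scatter). Set beside the earlier step on the first core, the two results do not differ: the same change on two cores in this assay, a 1.2-fold higher number (0.07 log units; within the scatter) from compound 2 to compound 1 and a 1.1-fold lower number (0.03 log units; within the scatter) from compound 3 to compound 4, 1.3-fold (0.10 log units) apart, within the scatter of two such steps. Among the compounds shown here, this shows that on these two cores the swap leaves no step that can be told from the scatter, but it does not show that a real effect of the change carries from one core to the other, as neither step is large enough to reveal one.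

The compounds shown hold only trifluoromethyl or chloro at this place on the ring. From the compounds shown here alone, whether an amine or a carboxylic acid there would give a clear step, and whether that step would match on both cores, remains open.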